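A few compounds are considered here, and "the series" means these few. Any claim that something is new, unique, unknown or untested is made for them only; others in the source may bear on it.

Three compounds share one core and differ in two places. Compound 1 `CC(=O)OCc1ccc2oc(=O)c(C(=O)Sc3cccc(Cl)c3)cc2c1` gives 65.8% in a functional assay on HT-1080 cells (Homo sapiens), read by transwell migration, with a stated time of 24 h, tested at 1 uM; a lower number here means a stronger effect, a higher number a weaker effect of the compound at the concentration tested. Compound 2 `CC(=O)OCc1ccc2oc(=O)c(C(=O)N(C)c3ccc(Cl)cc3)cc2c1` gives 98.6%, and the step of a number 32.8 percentage points higher from compound 1 to compound 2 (beyond the scatter) is the only measured change among these compounds. Compound 3 `CCC(=O)OCc1ccc2oc(=O)c(C(=O)Oc3cccc(Br)c3)cc2c1` gives 40.2%, the lowest of the three numbers, which here means the strongest effect; its nearest neighbour is compound 1, and compound 2 lies furthest from it.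

Compound 4 `CCCCC(=O)OCc1ccc2oc(=O)c(C(=O)Oc3cccc(Br)c3)cc2c1` differs from compound 3 by ethyl in place of hydrogen on a saturated chain carbon, two bonds along the chain from a carbonyl carbon, a lengthening of the chain that ends in a carbonyl. Among the compounds with values here, the single measured step, from compound 1 to compound 2, concerns the group on the other carbonyl carbon of the core, so it gives no guidance on lengthening this chain. Within the data shown here, with no step that bears on the change, the expectation is a step that stays within the scatter, a number 1.8 percentage points higher from compound 3 to compound 4 (within the scatter). Compound 4 is therefore expected to give about 42% in this assay, with a range from 25% to 65%.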

Compound 4, a percentage reported as activity, at one concentration (the size of the read-out at that concentration, not a potency): 63.3%
Compound 4: middle estimate off by 21.3 percentage points, on the low side, within the range that was stated.
By their numbers in this assay, from the lowest: compound 3; then compounds 4 and 1 (each within the scatter of the next); then compound 2.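

Within the data shown here, this is the first measured change at this chain, and it shows that the chain's length matters. In this assay, going from propanoyl to butylcarbonyl, with the rest of the molecule unchanged, gives a number 23.1 percentage points higher from compound 3 to compound 4 (beyond the scatter) and so a weaker effect at the concentration tested. No measurement shown here accounts for this loss of effect.

One step cannot show whether the effect keeps weakening with a longer chain such as hexanoyl, or how a branched chain or a chain ending in an amine or a carboxylic acid would behave. On these data alone, it is also open whether the same lengthening would give a similar step with another group on the other carbonyl carbon of the shared core, such as the (3-chlorophenyl)sulfanyl of compound 1.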